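This account rests on a few compounds, and the source may have more. Where it says the series, first, only, none or still open, it means among the compounds named here.

For the measured compounds named here, in a functional assay on HCT-116 cells (Homo sapiens) for cytotoxicity, with a stated time of 3 days (a higher number here means a weaker inhibitor, a lower number a stronger inhibitor), compound 2 (`C#Cc1nc(C(=O)Nc2ccccc2)cs1`) gives 4880 nM and holds the lower of the two numbers available so far, while compound 1 (`C#Cc1nc(C(=O)Nc2ccc(Cl)cc2)cs1`) gives 15900 nM on the same scale. For compound 3 (`C#CCNC1CCC(c2csc(C#C)n2)=C1C`) the reading > 40000 nM is a limit and not a number, so it cannot be ranked exactly.

The next compound to consider is compound 4 (`C#Cc1nc(C(=O)Nc2ccc(OC)cc2)cs1`), which differs from compound 2 in one place (methoxy in place of hydrogen on an aromatic carbon): methoxy in place of hydrogen on an aromatic carbon, para to a large group. Going by the values given here, the one measured step that bears on this change is the swap of chloro for hydrogen on an aromatic carbon (a 3.3-fold lower number from compound 1 to compound 2 (0.51 log units; beyond the scatter)), which is modest. Run in reverse, that step shows a group in place of hydrogen going with a higher number. Chloro and methoxy are different groups, however, and a single pair is thin evidence, so it guides the direction only loosely.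

A step no larger than that one, towards a higher number, is therefore expected, and the estimate amounts to a 1.5-fold higher number from compound 2 to compound 4 (0.19 log units; within the scatter) as an expected change in this assay for this pair. In this assay the estimate for compound 4 is 7500 nM with an expected range from 2500 nM to 20000 nM for this compound.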

Compound 4, half-maximal inhibitory concentration: 8390 nM
Compound 4: the middle estimate sits 1.1-fold (0.05 log units) below what was measured, within the range that was stated.
By their numbers in this assay, from the lowest: compounds 2, 4 and 1 (each within the scatter of the next, the first and the last beyond it). At a limit, above all of these: compound 3.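

In this assay methoxy on this aromatic carbon, para to a large group, gives a 1.7-fold higher number from compound 2 to compound 4 (0.24 log units; within the scatter) and so cannot be told apart from hydrogen. Methoxy in place of chloro on the same carbon gives a 1.9-fold lower number from compound 1 to compound 4 (0.28 log units; within the scatter) and so cannot be told apart from chloro either. The earlier step of a 3.3-fold lower number from compound 1 to compound 2 (0.51 log units; beyond the scatter) remains the only one here beyond the scatter, and with compound 4 lying within the scatter of both neighbours, that step does not show that any group at this place goes with a higher number.

The compounds shown leave open what a group of another kind on this carbon, such as an amine, a carboxylic acid or a longer chain, would do to the number. No measurement given here offers a reason for these small differences.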